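Replacing the (morpholin-4-yl)carbonyl group of compound 2

The source may report more compounds than this note shows. Statements on the series, on what has been measured and on what is new or still open speak of the compounds shown alone.

Measured so far in a functional assay on HCT-116 cells (Homo sapiens) for antiproliferative activity, read by MTT assay, with a stated time of 72 h; on this read-out higher numbers stand for weaker inhibition and lower numbers for stronger inhibition:
Compound 1 `C=CC(=O)N(CC(=O)OCC)c1nc(-c2ccccc2)cs1` gives > 30000 nM (a limit)
Compound 2 `C=CC(=O)N(CC(=O)N1CCOCC1)c1nc(-c2ccccc2)cs1` gives 14600 nM (a number)

Among the compounds with values here, compound 2 gives 14600 nM and holds the only true number so far. Compound 1 sits at the limit of > 30000 nM in this assay, at which 1 of the 2 values shown sits, and so offers a limit rather than a number.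

Compound 3 `C=CC(=O)N(Cc1cc(C)no1)c1nc(-c2ccccc2)cs1` has not yet been measured. It differs from compound 2 by 3-methyl-1,2-oxazol-5-yl in place of (morpholin-4-yl)carbonyl on a saturated chain carbon bound to an amide-type nitrogen and keeps the shared core. Within the data shown here, only one measured step bears on it, an at least 2.0-fold lower number from compound 1 to compound 2 (0.31 log units; beyond the scatter), and that step alters the group on the same carbonyl that compound 3 gives up. Its size is only a lower bound, and it does not cover the replacement of the whole (morpholin-4-yl)carbonyl group. No step beyond the scatter is therefore expected, and the estimated step is a 1.2-fold lower number from compound 2 to compound 3 (0.09 log units; within the scatter) as a result. In this assay the estimate for compound 3 is 12000 nM with an expected range of 4000 nM to 30000 nM overall.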

Compound 3, half-maximal inhibitory concentration: > 30000 nM
Compound 3: a limit, no number; the forecaster's own chance of this, stated with the estimate: 25%; middle value at least 2.5-fold (0.39 log units) away from the limit.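

In this assay, the change shows that this place, on a saturated chain carbon bound to an amide-type nitrogen, does not accept every group in place of (morpholin-4-yl)carbonyl: swapping in 3-methyl-1,2-oxazol-5-yl removes the carbonyl itself and gives an at least 2.0-fold higher number from compound 2 to compound 3 (0.31 log units; beyond the scatter). Within the data shown here, the value of compound 3 is a limit and not a number: the limit of > 30000 nM in this assay, at which 2 of the 3 values shown sit. Compound 2 thus remains the only one with a true number, although compound 1 keeps a carbonyl as well, and the step between the two limits cannot be read.

Going by these compounds, it remains open whether the carbonyl or the morpholin-4-yl ring accounts for the difference, which a piperidin-1-yl or dimethylamino group on the same carbonyl, or a morpholin-4-yl directly on the chain carbon, could separate. On these data alone, the step is only a lower bound, so its true size also stays open.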